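The source may report more compounds than this note shows. Statements on the series, on what has been measured and on what is new or still open speak of the compounds shown alone.

Measured compounds:
Compound 1 `CCCc1nc2ccccc2c(=O)n1/N=C/c1ccc(Oc2ccc(Cl)cc2)cc1` gives 5.78 in a physicochemical assay for lipophilicity, in phosphate buffer, measured as octanol-water partition; a higher number here means a more lipophilic compound, a lower number a more polar compound.
Compound 2 `CCCc1nc2ccccc2c(=O)n1/N=C/c1ccc(Oc2ccc([N+](=O)[O-])cc2)cc1` gives 5.18 in this assay.

Compound 2 stands lowest of the two numbers; its nearest neighbour is compound 1, and the step of a number 0.60 log units lower from compound 1 to compound 2 (beyond the scatter) separates them. The next compound, compound 3 `CCCc1nc2ccccc2c(=O)n1/N=C/c1ccc(Oc2ccc(C)cc2)cc1`, is not yet measured. It differs from compound 2 in one place: methyl in place of nitro on an aromatic carbon, on an aromatic carbon of a six-membered aromatic ring of carbon only, para to a large group. Among the measured compounds shown here, only one measured step bears on this change, the one from compound 1 to compound 2, in which nitro in place of chloro brought a modest drop beyond the scatter. Taking the nitro away again is therefore expected to move the number back toward that of compound 1, and the step of a number 0.52 log units higher from compound 2 to compound 3 (beyond the scatter) is expected. Compound 3 is estimated at 5.7, within a range from 5.3 to 6.1.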

Compound 3, partition coefficient: 5.45
Beside the measured number, compound 3's estimate is 0.25 log units above it, within the range that was stated.
By their numbers in this assay, from the lowest: compounds 2 and 3 (each within the scatter of the next); then compound 1.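

In this assay, methyl in place of nitro at this place, on an aromatic carbon para to a large group, gives a number 0.27 log units higher from compound 2 to compound 3 (within the scatter) and so leaves the two compounds indistinguishable, while methyl in place of chloro gives a number 0.33 log units lower from compound 1 to compound 3 (beyond the scatter) as a step of its own. Among these three compounds, then, the chloro compound stands apart from both the nitro and the methyl compounds, and taking out the nitro does not by itself return the number to that of compound 1. Nothing measured here accounts for this grouping.

Going by these compounds, whether an amine, a carboxylic acid or a methoxy group at this place would fall with compound 1 or with compounds 2 and 3 remains open. So does whether a bromo or fluoro group would stand with the chloro compound.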